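Tetrahydroisoquinoline Amide in Place of a Diisopropylamide

The source may hold more compounds than are shown below. What is called first, only, known or untested is meant among the compounds shown, and "the series" means these compounds.

Compound 1 `CC(C)N(C(=O)CCNC(=O)c1ccc(S(C)(=O)=O)c([N+](=O)[O-])c1)C(C)C` was tested in an assay on isolated protein for inhibition of thyroid hormone receptor beta (Homo sapiens), read by fluorescence polarization; a lower number here means a stronger inhibitor, a higher number a weaker inhibitor. For compound 1 the assay reports only the limit > 60000 nM, not a number. Compound 2 `CCCN(C(=O)CN(C)C(=O)c1ccc(S(C)(=O)=O)c([N+](=O)[O-])c1)c1ccccc1` likewise reaches only the limit > 60000 nM. Compound 3 `CS(=O)(=O)c1ccc(C(=O)NCC(=O)N2CCc3ccccc3C2)cc1[N+](=O)[O-]` gives a measured value of 46000 nM. Compound 1 thus stands at the limit of > 60000 nM in this assay, at which 2 of the 3 values shown sit. Compound 4 `CS(=O)(=O)c1ccc(C(=O)NCCC(=O)N2CCc3ccccc3C2)cc1[N+](=O)[O-]` has not been measured; it differs from compound 1 by 1,2,3,4-tetrahydroisoquinolin-2-yl in place of diisopropylamino on a carbonyl carbon. Compound 3 carries the same 1,2,3,4-tetrahydroisoquinolin-2-yl group and gives 46000 nM. On that basis a step from the limit toward stronger inhibition, no larger than the scatter, is expected for compound 4 with an at least 1.2-fold lower number from compound 1 to compound 4 (0.07 log units; that floor lies within the scatter). Compound 4 is estimated at 50000 nM, between 15000 nM and 60000 nM.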

Compound 4, half-maximal inhibitory concentration: > 60000 nM
Compound 4 ended at the assay's limit; the forecaster's own chance of this, stated with the estimate: 50%; middle value at least 1.2-fold (0.07 log units) away from the limit.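

Compound 1 and compound 4 both stand only at a limit in this assay, so the step between them cannot be read. The compounds shown leave open whether 1,2,3,4-tetrahydroisoquinolin-2-yl in place of diisopropylamino on a carbonyl carbon changes inhibition at all.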